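The source may hold more compounds than are shown below. What is called first, only, known or untested is meant among the compounds shown, and "the series" means these compounds.

Of the compounds shown here, two have already been measured in an assay on membranes from brain for displacement of a labelled ligand from Neuronal acetylcholine receptor; alpha4/beta2 (Rattus norvegicus), with a stated time of 3 h; a higher number here means a weaker inhibitor, a lower number a stronger inhibitor. Compound 1 `CCCCOc1ccc(/C=C2\CCCN=C2c2cccnc2)cc1` gives 1960 nM, and compound 2 `Cc1cc(C)c(/C=C2\CCCN=C2c2cccnc2)c(C)c1` gives 520 nM. Compound 1 therefore stands at the weaker end of the two, its number being the higher, with compound 2 the nearer and stronger of the pair by a margin beyond the scatter. For the measured compounds named here, the two differ in more than one place, so no single step between them is drawn; their values only show that a ring bearing three methyl groups is the stronger of the two arrangements seen so far.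

Compound 3 `N#Cc1ccc(/C=C2\CCCN=C2c2cccnc2)cc1` remains to be measured in this assay. It is reached from compound 1 by one change: cyano in place of butoxy on an aromatic carbon. Going by the values given here, no step between measured compounds covers a change of this kind, so the expected size rests on the values alone. A modest gain in binding is expected, with the step from compound 1 to compound 3 estimated at a 2.5-fold lower number from compound 1 to compound 3 (0.39 log units; beyond the scatter). Compound 3 is accordingly expected to give about 800 nM in this assay, with a range from 200 nM to 3200 nM.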

Compound 3, inhibition constant: 1230 nM
For compound 3 the middle estimate is 1.5-fold (0.19 log units) below the measured one; measured number inside the range.
By their numbers in this assay, from the lowest: compound 2; then compounds 3 and 1 (each within the scatter of the next).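

In this assay, for the compounds shown here, the exchange of butoxy for cyano on the aromatic carbon para to a large group amounts to a 1.6-fold lower number from compound 1 to compound 3 (0.20 log units; within the scatter), the first reading of a change at this position. Within this single pair, a group of 5 heavy atoms with oxygen gives way to one of 2 heavy atoms with a triple bond, each counted with 1 hydrogen-bond acceptor, and the result stays inside the usual variation of the measurement, so compound 1 and compound 3 cannot be ranked against each other. Nothing available here accounts for this closeness, and the pair by itself offers no explanation of it.

From the compounds shown here alone, whether this tolerance extends to other groups at the same position remains open: an amine, a carboxylic acid, a hydrogen atom or a longer alkoxy chain could each move the number in either direction or leave it in place. Compound 2, with its three methyl groups, still differs from compound 1 and from compound 3 in more than one place, and what any single methyl group contributes remains unresolved.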